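The source may report more compounds than this note shows. Statements on the series, on what has been measured and on what is new or still open speak of the compounds shown alone.

Measured in an ADME assay on the whole organism (Mus musculus, strain CD1) for pharmacokinetics, read by LC-MS, using cassette dosing, with a stated time of 24 h, at a dose of 0.4 mg/kg by the intravenous route; on this read-out lower numbers stand for narrower distribution and higher numbers for wider distribution into tissues: compound 2 `Cc1cn(-c2cc(NC(=O)c3ccc(C)c(Oc4ccccc4)c3)cc(C(F)(F)F)c2)cn1` gives 1.69 L/kg; compound 1 `Cc1cn(-c2cc(CN3CCC[C@H](N)C3)cc(NC(=O)c3ccc(C)c(Nc4nccc(-c5ccc(F)cc5)n4)c3)c2)cn1` gives 13.3 L/kg; compound 3 `Cc1cn(-c2cc(NC(=O)c3ccc(C)c(Oc4cccc5ccncc45)c3)cc(N3CCN(C)CC3)c2)cn1` gives 6.7 L/kg.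

Compound 2 stands lowest of the three on this assay. Its nearest neighbour is compound 3 and its furthest is compound 1, and both gaps lie beyond the scatter, so compound 2 is clearly the narrowest distributor here. Compound 4 `Cc1cn(-c2cc(CN3CCC[C@H](N)C3)cc(NC(=O)c3ccc(C)c(Oc4ccccc4)c3)c2)cn1` differs from compound 2 in one place: (3-aminopiperidin-1-yl)methyl in place of trifluoromethyl on an aromatic carbon. Among the compounds with values here, no measured pair shows this exact change, so the step is an expectation only. An upward step beyond the scatter is expected, because compound 1, which carries the same entering group, gives 13.3 L/kg. The expected step is a 4.7-fold higher number from compound 2 to compound 4 (0.68 log units; beyond the scatter). Compound 4 is estimated at 8 L/kg, within 3.5 L/kg to 18 L/kg.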

Compound 4, volume of distribution at steady state: 9.13 L/kg
Compound 4: the middle estimate sits 1.1-fold (0.06 log units) below what was measured; low and high end bracket the measured number.
By their numbers in this assay, from the lowest: compound 2; then compounds 3, 4 and 1 (each within the scatter of the next).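

In this assay, within the data shown here, putting (3-aminopiperidin-1-yl)methyl in place of trifluoromethyl on this aromatic carbon gives a 5.4-fold higher number from compound 2 to compound 4 (0.73 log units; beyond the scatter) and so provides the first direct comparison at this position. The step lies beyond the scatter, so the group at this position clearly matters for this read-out. Nothing shown here explains the rise.

From the compounds shown here alone, it remains open whether the ring or its amino group accounts for the step, a question that a plain piperidin-1-ylmethyl group could address. The opposite stereoisomer of the aminopiperidine also remains untested in the compounds shown.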